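The source may hold more compounds than are shown below. What is called first, only, known or untested is meant among the compounds shown, and "the series" means these compounds.

Two compounds share one core, and both have been tested in an assay on HEK-293T cells for inhibition of Bile acid receptor (Homo sapiens), read by a beta-lactamase reporter, with a stated time of 16 h; on this read-out lower numbers stand for stronger inhibition and higher numbers for weaker inhibition. Compound 1 `Cc1ccc(-c2nn(-c3cccc(Cl)c3)cc2C(=O)Nc2ccc(C)c(S(=O)(=O)N3CCOCC3)c2)cc1` carries a 3-chlorophenyl group on an aromatic nitrogen and gives 5910 nM. Compound 2 `Cc1ccc(-c2nn(C(C)C)cc2C(=O)Nc2ccc(C)c(S(=O)(=O)N3CCOCC3)c2)cc1` carries an isopropyl group at that position instead and gives 1690 nM. For the measured compounds named here, the only step between measured compounds, a 3.5-fold lower number from compound 1 to compound 2 (0.54 log units; beyond the scatter), is therefore the swap of an aromatic ring for a small alkyl group, and it lowered the number. Of the two values shown, compound 2 is the lower one.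

Compound 3 `Cc1ccc(-c2nn(Cc3ccc4ccccc4c3)cc2C(=O)Nc2ccc(C)c(S(=O)(=O)N3CCOCC3)c2)cc1` has not been measured yet. It differs from compound 2 in one place: (naphthalen-2-yl)methyl in place of isopropyl on an aromatic nitrogen. The change goes back toward a ring-bearing group at the same nitrogen, though now two fused aromatic rings are attached through a one-carbon link rather than directly. Going by the values given here, only the step from compound 1 to compound 2 bears on this, and it pointed toward smaller groups giving lower numbers; the reverse move is expected to give a higher number, of modest size, as a 2.1-fold higher number from compound 2 to compound 3 (0.32 log units; beyond the scatter). Compound 3 is thus estimated at 3500 nM, with a likely range from 900 nM to 14000 nM.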

Compound 3, half-maximal inhibitory concentration: 844 nM
Beside the measured number, compound 3's estimate is 4.1-fold (0.62 log units) above it; measured number below the stated range.
By their numbers in this assay, from the lowest: compounds 3 and 2 (each within the scatter of the next); then compound 1.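

In this assay, the aromatic nitrogen accepts a far larger group than isopropyl: exchanging isopropyl for (naphthalen-2-yl)methyl gives a 2.0-fold lower number from compound 2 to compound 3 (0.30 log units; within the scatter), so the earlier hint that smaller groups give lower numbers does not hold for this pair. Carrying aromatic rings at this nitrogen is also not enough to raise the number, since replacing 3-chlorophenyl with (naphthalen-2-yl)methyl gives a 7.0-fold lower number from compound 1 to compound 3 (0.85 log units; beyond the scatter), although that swap alters the ring system and adds a one-carbon link together, so neither change can be credited on its own. No available data explain these differences.

The compounds shown leave open whether the one-carbon link or the second fused ring matters more, a question that a benzyl group, with a single phenyl ring on the same link, could help to separate. They also leave open how a directly attached naphthalen-2-yl group, a saturated cyclohexylmethyl group or a longer chain such as n-butyl would compare at this nitrogen.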